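Swapping a Halopyridine Ring on a Sulfonyl Core

The source may hold more compounds than are shown below. What is called first, only, known or untested is meant among the compounds shown, and "the series" means these compounds.

Compounds measured so far:
compound 1 `CC1CCN(C2CCN(S(=O)(=O)c3cccnc3Cl)CC2)CC1`: > 10000 nM
compound 2 `CC1CCN(C2CCN(S(=O)(=O)c3ccc(OCc4ccccc4)cc3)CC2)CC1`: > 5000 nM
compound 3 `CC1CCN(C2CCN(C(=O)c3ccc(OC(F)(F)F)cc3)CC2)CC1`: > 5000 nM

In an ADME assay on HCT-116 cells (Homo sapiens) for cytotoxicity, read by CellTiter-Glo, with a stated time of 72 h (on this read-out lower numbers stand for stronger inhibition and higher numbers for weaker inhibition), compound 1 gives > 10000 nM, which is a limit of the assay rather than a number. Compound 2 also sits at a limit in this assay, > 5000 nM. Compound 3 likewise gives only a limit, > 5000 nM. None of the three compounds shown therefore has a measured value; all three stay at the weak end of the range, as shown by the limit of > 10000 nM in this assay, at which 1 of the 3 values shown sits, and (the limit of > 5000 nM in this assay, at which 2 of the 3 values shown sit).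

The unmeasured compound 4 `CC1CCN(C2CCN(S(=O)(=O)c3cncc(Br)c3)CC2)CC1` differs from compound 1 in a single place: 5-bromopyridin-3-yl in place of 2-chloropyridin-3-yl on a sulfonyl sulfur. Among the compounds with values here, no step between measured compounds is available, so no size can be read from the data for such a swap. Given that compound 1 and both other compounds stay at limits, no step beyond the usual scatter is expected; the step from compound 1 to compound 4 is expected to be a step that the limit leaves unreadable from compound 1 to compound 4. Compound 4 is thus expected to give about 15000 nM in this assay, within a range of 5000 nM to 50000 nM, most likely reported again only as a limit.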

Compound 4, half-maximal inhibitory concentration: > 10000 nM
Compound 4: only a limit was reported; the forecaster's own chance of this, stated with the estimate: 85%; the middle value does not contradict the limit.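

Compound 1 and compound 4 both stay at a limit in this assay, and no step can be read between them. The compounds shown leave open whether 5-bromopyridin-3-yl in place of 2-chloropyridin-3-yl changes the result at all, and what actual value any of the four compounds would give in this assay.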